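Removing the Nitro Group From a Sigma-1 Guanidine

A few compounds are considered here, and "the series" means these few. Any claim that something is new, unique, unknown or untested is made for them only; others in the source may bear on it.

Of the compounds shown here, three of a shared guanidine core have been measured in an assay on membranes from brain (Cavia porcellus) for binding affinity to Sigma non-opioid intracellular receptor 1 (Homo sapiens), read by radioligand binding; on this read-out higher numbers stand for weaker inhibition and lower numbers for stronger inhibition. Compound 1 `Cc1cccc(NC(=N)N(C)c2cccc(C)c2)c1` gives 247 nM. Compound 2 `CCc1cccc(NC(=N)Nc2cccc3ccccc23)c1` gives 54 nM. Compound 3 `CN(C(=N)Nc1cccc2ccccc12)c1cccc([N+](=O)[O-])c1` gives 6260 nM, which is the highest of the three numbers; its gap to compound 1 is the smaller one and its gap to compound 2 the larger, and both gaps lie beyond the usual scatter, so compound 3 stands clearly apart as the weakest binder among them.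

Compound 4 `CN(C(=N)Nc1cccc2ccccc12)c1ccccc1` has not yet been measured. It differs from compound 3 by a single change: hydrogen in place of nitro on an aromatic carbon. For the measured compounds named here, no measured pair in this set shows that exact change, so its size cannot be read off directly. What the numbers do show is that the two compounds without a nitro group both sit far below compound 3, and compound 4 joins that nitro-free group while keeping the rest of the structure of compound 3 intact.

The expected step is therefore downward and beyond the scatter, as a 14-fold lower number from compound 3 to compound 4 (1.14 log units; beyond the scatter) expresses. Compound 4 is estimated at 450 nM, with a range from 80 nM to 2500 nM.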

Compound 4, half-maximal inhibitory concentration: 2900 nM
Compound 4: middle estimate off by 6.4-fold (0.81 log units), on the low side; measured number outside the range, above it.
By their numbers in this assay, from the lowest: compound 2; then compound 1; then compound 4; then compound 3.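

In this assay, for the compounds shown here, the swap of hydrogen in place of nitro on an aromatic carbon, meta to a large group, gives a 2.2-fold lower number from compound 3 to compound 4 (0.33 log units; beyond the scatter) as the first direct reading of this change in the set, which the earlier compounds could only hint at from a distance. The nitro group at this position therefore does matter to the number, but only modestly, and with the nitro gone compound 4 still reads 2900 nM in this assay, so the loss of this one group accounts for a small step rather than a large one. Nothing available here gives a measured reason for the size of this step, so the result stands as an observation without an explanation.

The compounds shown leave open how other groups on this same aromatic carbon, such as an amine, a chlorine atom or a carboxylic acid, would read against hydrogen and nitro in this assay on the same core. They also leave open whether the same swap would give a step of similar size on a core carrying different groups elsewhere.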